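From 2-bromobenzyl to propargyl on the sulfur chain

A few compounds are considered here, and "the series" means these few. Any claim that something is new, unique, unknown or untested is made for them only; others in the source may bear on it.

Compound 1 `Cc1cc(Nc2cc(-c3ccccc3)[nH]n2)n2nc(SCc3ccc([N+](=O)[O-])cc3)nc2n1` gives 43600 nM
Compound 2 `Cc1cc(Nc2cc(-c3ccccc3)[nH]n2)n2nc(SCc3cccc(Br)c3)nc2n1` gives > 50000 nM
Compound 3 `Cc1cc(Nc2cc(-c3ccccc3)[nH]n2)n2nc(SCc3ccccc3Br)nc2n1` gives 41100 nM

In an ADME assay on GES1 cells (Homo sapiens) for inhibition, read by MTT assay, with a stated time of 72 h (a lower number here means a stronger inhibitor, a higher number a weaker inhibitor), these three compounds share one core and differ only in the aromatic group on a saturated chain carbon bound to a sulfur. The entry for compound 2 (> 50000 nM) is a limit of the assay and not a number. Compound 3 (41100 nM) sits within the scatter of compound 1 (43600 nM).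

In compound 4 `C#CCSc1nc2nc(C)cc(Nc3cc(-c4ccccc4)[nH]n3)n2n1` ethynyl stands in place of 2-bromophenyl on a saturated chain carbon bound to a sulfur, which turns 2-bromobenzyl into propargyl (ethynyl in place of 2-bromophenyl on a saturated chain carbon bound to a sulfur). Among the measured compounds shown here, three measured steps bear on this place, and each exchanges one aromatic group for another: (a 1.1-fold lower number from compound 1 to compound 3 (0.03 log units; within the scatter)), (an at least 1.1-fold higher number from compound 1 to compound 2 (0.05 log units; that floor lies within the scatter)) and (an at least 1.2-fold lower number from compound 2 to compound 3 (0.08 log units; that floor lies within the scatter)). All three lie within the scatter. None of them removes the ring, so they are only a loose guide to this larger change.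

With compound 3 at (41100 nM) and the step from its closest neighbour this small (a 1.1-fold lower number from compound 1 to compound 3 (0.03 log units; within the scatter)), no change beyond the scatter is expected, and no direction can be favoured. The expected step (a 1.1-fold higher number from compound 3 to compound 4 (0.04 log units; within the scatter)) is estimated to stay small. Compound 4 is estimated at 45000 nM within an expected range (22000 nM to 80000 nM).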

Compound 4, half-maximal inhibitory concentration: 45700 nM
Compound 4: the middle estimate sits 1.0-fold (0.01 log units) below what was measured; the measured number falls inside the stated range.
By their numbers in this assay, from the lowest: compounds 3, 1 and 4 (each within the scatter of the next). At a limit, above all of these: compound 2.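

In this assay, among the compounds shown here, the exchange of 2-bromophenyl for ethynyl takes away the aromatic ring altogether and leaves the number within the scatter (a 1.1-fold higher number from compound 3 to compound 4 (0.05 log units; within the scatter)), whereas the earlier steps only swapped one aromatic group for another. The comparison with the 4-nitrophenyl of compound 1 reads the same (a 1.0-fold higher number from compound 1 to compound 4 (0.02 log units; within the scatter)), and the comparison with the 3-bromophenyl of compound 2 gives only a floor, which also lies within the scatter (an at least 1.0-fold lower number from compound 2 to compound 4 (0.03 log units; that floor lies within the scatter)). The entry for compound 2 is a limit of the assay and not a number: the limit of > 50000 nM in this assay, at which 1 of the 4 values shown sits.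

Across these four compounds, then, a small propargyl group on the sulfur and the larger benzyl groups of compound 1 and compound 3 cannot be told apart in this assay. Still open is whether an amine, a carboxylic acid or a longer chain on this saturated chain carbon bound to a sulfur would move the number beyond the scatter, and the compounds shown give no sign of which way it would go.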